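Aryl variation on the shared core: toward compound 4

This account rests on a few compounds, and the source may have more. Where it says the series, first, only, none or still open, it means among the compounds named here.

Within the data shown here, compound 3 `Nc1nc(-c2ccccn2)nc2sc(Cc3ccccc3)cc12` gives 3710 nM in a functional assay on CHO-K1 cells for antagonist activity at adenosine receptor A1 (Homo sapiens), read by a beta-galactosidase reporter and cAMP accumulation, with stated times of 15 min and 6 h (on this read-out lower numbers stand for stronger inhibition and higher numbers for weaker inhibition), the highest of the three numbers so far. Compound 1 `Cn1cnc(-c2nc(N)c3cc(Cc4ccccc4)sc3n2)c1` gives 2330 nM and compound 2 `COc1cccc(-c2nc(N)c3cc(Cc4ccccc4)sc3n2)c1` gives 266 nM. The step of a 1.6-fold higher number from compound 1 to compound 3 (0.20 log units; within the scatter) lies within the scatter, whereas a 14-fold higher number from compound 2 to compound 3 (1.14 log units; beyond the scatter) is large; an 8.8-fold lower number from compound 1 to compound 2 (0.94 log units; beyond the scatter) shows the same contrast from the other side, with compound 2, carrying 3-methoxyphenyl, giving the lowest number. Compound 4 `N#Cc1cncc(-c2nc(N)c3cc(Cc4ccccc4)sc3n2)c1` carries 5-cyanopyridin-3-yl in place of pyridin-2-yl on an aromatic carbon. Both bearing steps involve a six-membered heteroaryl at this position, and the present change stays within heteroaryls while adding a nitrile, so only a modest lowering in this assay is expected, short of the gap to compound 2. For compound 4 the expected value is 1600 nM, range 450 nM to 5500 nM, an estimated step of a 2.3-fold lower number from compound 3 to compound 4 (0.37 log units; beyond the scatter).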

Compound 4, inhibition constant: 1160 nM
The estimate for compound 4 lay 1.4-fold (0.14 log units) above the measured number; the range from low to high includes it.
By their numbers in this assay, from the lowest: compound 2; then compounds 4, 1 and 3 (each within the scatter of the next, the first and the last beyond it).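

Replacing pyridin-2-yl with 5-cyanopyridin-3-yl in this assay gives a step beyond the scatter (a 3.2-fold lower number from compound 3 to compound 4 (0.50 log units; beyond the scatter)), so the choice of heteroaryl at this position can move the number, which the pair of compounds 1 and 3 did not show. The 3-methoxyphenyl group still gives the lower number (a 4.4-fold higher number from compound 2 to compound 4 (0.64 log units; beyond the scatter)), while 1-methyl-1H-imidazol-4-yl remains level with the new group (a 2.0-fold lower number from compound 1 to compound 4 (0.30 log units; within the scatter)). No evidence here bears on the reason for these steps.

The step changes both the ring attachment and the nitrile, and these remain inseparable. An unsubstituted pyridin-3-yl would separate them, and an amine or carboxylic acid in place of the nitrile would test that substituent.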